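Fluoro for Chloro on the Weaker Diastereomer

The source may hold more compounds than are shown below. What is called first, only, known or untested is meant among the compounds shown, and "the series" means these compounds.

Compound 1 `CC[C@H](NC(C)=O)c1cc(Cl)ccc1C1CCN(C(=O)[C@H]2CN(C(C)(C)C)C[C@@H]2c2ccc(Cl)cc2Cl)CC1` and compound 2 `CC[C@H](NC(C)=O)c1cc(Cl)ccc1C1CCN(C(=O)[C@@H]2CN(C(C)(C)C)C[C@H]2c2ccc(Cl)cc2Cl)CC1` share every atom and bond and differ only in the configuration drawn at two ring carbons. Among the measured compounds shown here, in an assay on CHO cells for displacement of a labelled ligand from Melanocortin receptor 4 (Homo sapiens) (a lower number here means a stronger inhibitor, a higher number a weaker inhibitor), compound 1 gives 3.3 nM, while compound 2 gives 17.9 nM, the higher of the two numbers measured so far. For the measured compounds named here, the only measured step, a 5.4-fold higher number from compound 1 to compound 2 (0.73 log units; beyond the scatter), rests on the fact that compounds 1 and 2 differ only in the configuration as drawn and says nothing about substituents on the aromatic rings. Compound 3 `CC[C@H](NC(C)=O)c1cc(Cl)ccc1C1CCN(C(=O)[C@@H]2CN(C(C)(C)C)C[C@H]2c2ccc(F)cc2Cl)CC1` keeps the configuration of compound 2 and carries a single change: fluoro in place of chloro on an aromatic carbon. Going by the values given here, no measured step bears on this exchange, so the stereochemical step offers no guide to its direction, and a halogen swap of one atom for one atom is expected to move the number little. Compound 3 is therefore expected near 25 nM, within 8 nM to 80 nM, so that a 1.4-fold higher number from compound 2 to compound 3 (0.15 log units; within the scatter) is estimated to stay within the scatter.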

Compound 3, half-maximal inhibitory concentration: 216 nM
Beside the measured number, compound 3's estimate is 8.6-fold (0.94 log units) below it; measured number outside the range, above it.
By their numbers in this assay, from the lowest: compound 1; then compound 2; then compound 3.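

On the configuration of compound 2, the exchange of 2,4-dichlorophenyl for 2-chloro-4-fluorophenyl gives a 12-fold higher number from compound 2 to compound 3 (1.08 log units; beyond the scatter) in this assay. The earlier compounds shown here spoke only to configuration, whereas this step shows that the number also responds strongly to the identity of the halogen at this place, para to a large group, even though one heavy atom replaces one heavy atom and the counts of hydrogen-bond donors and acceptors stay the same. Nothing in the information available accounts for the size or direction of this step.

On these data alone, whether fluoro in place of chloro moves the number as far on the configuration of compound 1 remains open. So does how a bromo, a methyl or a plain hydrogen at this place would compare with chloro and fluoro.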